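Adding an Ethyl Group to Compound 3

The source may hold more compounds than are shown below. What is called first, only, known or untested is meant among the compounds shown, and "the series" means these compounds.

Three compounds, each with a different core, have been measured in a functional assay on HCT-116 cells (Homo sapiens) for antiproliferative activity, read by MTT assay; on this read-out lower numbers stand for stronger inhibition and higher numbers for weaker inhibition. Compound 1 `Nc1ccccc1NC(=O)c1ccc(Cn2nnc3ccccc3c2=O)cc1` gives 600 nM, compound 2 `Nc1ccccc1NC(=O)c1ccc(Cn2c(=O)oc3ccccc3c2=O)cc1` gives 300 nM, and compound 3 `Nc1ccccc1NC(=O)c1ccc(Cn2c(=O)[nH]c3ccsc3c2=O)cc1` gives 400 nM. Compound 3 stands within the usual scatter of both other compounds, so these numbers do not separate it from either one.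

Compound 4 `CCn1c(=O)n(Cc2ccc(C(=O)Nc3ccccc3N)cc2)c(=O)c2sccc21` differs from compound 3 by a single change, ethyl in place of hydrogen on an aromatic nitrogen. Among the compounds with values here, no two measured compounds differ in only one place, so the data offer no direct guide to this change. The only clue is the narrow spread across three different cores, with compound 3 at 400 nM in the middle. On that basis, no change beyond the scatter is expected in this assay, with a slightly weaker result somewhat more likely than a stronger one. The expected step is a 1.3-fold higher number from compound 3 to compound 4 (0.10 log units; within the scatter). For compound 4, the estimated value is 500 nM, with a likely range from 200 nM to 1200 nM.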

Compound 4, half-maximal inhibitory concentration: 800 nM
The estimate for compound 4 lay 1.6-fold (0.20 log units) below the measured number; low and high end bracket the measured number.
By their numbers in this assay, from the lowest: compounds 2, 3, 1 and 4 (each within the scatter of the next, the first and the last beyond it).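

Within the data shown here, this is the first step in the set that changes only one place: the aromatic nitrogen that carries a hydrogen in compound 3 carries an ethyl group in compound 4. In this assay, this change gives a 2.0-fold higher number from compound 3 to compound 4 (0.30 log units; within the scatter), so the hydrogen on this nitrogen can be replaced by ethyl without a shift that stands clear of ordinary repeat variation. Nothing available explains the size or direction of this step.

Going by these compounds, whether methyl, a longer chain such as propyl, or a chain ending in an amine or a carboxylic acid would move the number beyond the scatter remains open. Among these compounds, with only one pair, it also remains unclear whether any trend exists at this nitrogen.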